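Inverting the Ring Stereocentre of Compound 3

This account rests on a few compounds, and the source may have more. Where it says the series, first, only, none or still open, it means among the compounds named here.

Compound 3 `COc1c(C)cnc(CN2c3nc(N)nc(Cl)c3NC(=O)[C@H]2C)c1C` gives 220 nM in a functional assay on SK-BR-3 cells (Homo sapiens) for inhibition; a lower number here means a stronger inhibitor, a higher number a weaker inhibitor. Compound 2 `COc1c(C)cnc(CN2c3nc(N)nc(Cl)c3NC(=O)[C@@H]2CC(C)C)c1C` gives 230 nM, and compound 1 `COc1c(C)cnc(CN2c3nc(N)nc(Cl)c3NC(=O)[C@@H]2C(C)C)c1C` gives 430 nM; the gap between compound 3 and either is within the scatter. Among the compounds with values here, the only measured step, a 1.9-fold lower number from compound 1 to compound 2 (0.27 log units; within the scatter), swaps one chain for another on the saturated ring carbon and stays within the scatter. Compound 4 `COc1c(C)cnc(CN2c3nc(N)nc(Cl)c3NC(=O)[C@@H]2C)c1C` differs from compound 3 in another way: the two compounds have the same atoms and bonds and differ only in configuration as drawn: 1 of 1 stereo elements differ; a stereocentre at a saturated ring carbon is drawn R in compound 3 and S in compound 4. No measured step involves a change of configuration, so nothing shown predicts its size or direction, and mirror-image pairs can differ widely. The estimate for compound 4 in this assay is therefore 550 nM, spanning 150 nM to 3000 nM, and the expected step of a 2.5-fold higher number from compound 3 to compound 4 (0.40 log units; beyond the scatter) is uncertain.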

Compound 4, half-maximal inhibitory concentration: 250 nM
For compound 4 the middle estimate is 2.2-fold (0.34 log units) above the measured one; low and high end bracket the measured number.
By their numbers in this assay, from the lowest: compounds 3, 2, 4 and 1 (each within the scatter of the next).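

In this assay, inverting the ring stereocentre gives a 1.1-fold higher number from compound 3 to compound 4 (0.06 log units; within the scatter), so with methyl on this ring carbon the two configurations are not told apart, and the comparison is a clean one: the fact that compounds 3 and 4 differ only in the configuration as drawn. Changing the chain on this carbon also stays within the scatter, with a 1.1-fold higher number from compound 2 to compound 4 (0.04 log units; within the scatter) and a 1.7-fold lower number from compound 1 to compound 4 (0.24 log units; within the scatter). As far as these compounds go, whether inversion would read the same with isopropyl or isobutyl in place of methyl stays open. So does how a hydroxymethyl or aminomethyl group on this ring carbon would read.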